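Aryl swap at the core of the imidazopyrazine series

A few compounds are considered here, and "the series" means these few. Any claim that something is new, unique, unknown or untested is made for them only; others in the source may bear on it.

Of the compounds shown here, two measured so far share one core. Compound 1 `Fc1ccc(-c2cn3ccnc3c(-c3ccc4ncn(C5CCCCC5)c4c3)n2)cc1` carries 4-fluorophenyl and in a functional assay on NCI-H226 cells (Homo sapiens) for inhibition, read by sulforhodamine B assay, with a stated time of 48 h, tested at 10 uM (a lower number here means less inhibition, a higher number more inhibition at the concentration tested (going by the name of the read-out)), compound 1 gives 23.3%. For the measured compounds named here, compound 2 `c1cn2cc(-c3ccsc3)nc(-c3ccc4ncn(C5CCCCC5)c4c3)c2n1` carries thiophen-3-yl in that position, and in this assay compound 2 gives 6.34%, the lowest of the two numbers, with the single step of a number 17 percentage points lower from compound 1 to compound 2 (beyond the scatter). Compound 3 `FC(F)(F)c1cccc(-c2cn3ccnc3c(-c3ccc4ncn(C5CCCCC5)c4c3)n2)c1` is the next member: 3-(trifluoromethyl)phenyl in place of thiophen-3-yl on an aromatic carbon. Going by the values given here, only the step from compound 1 to compound 2 bears on this, and it reverses the direction of exchange in part, a five-membered ring with one hetero atom leaving and a six-membered ring of carbon only entering, as in compound 1. Compound 3 is therefore expected to move upward by a number 11.7 percentage points higher from compound 2 to compound 3 (beyond the scatter), because compound 1 with its six-membered ring of carbon only gives 23.3%. Compound 3 is estimated at 18%, within 3% to 38%.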

Compound 3, a percentage reported as inhibition, at one concentration (the size of the read-out at that concentration, not a potency): 1.55%
For compound 3 the middle estimate is 16.5 percentage points above the measured one, and the stated range ends above it.
By their numbers in this assay, from the lowest: compounds 3 and 2 (each within the scatter of the next); then compound 1.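

In this assay the exchange of thiophen-3-yl for 3-(trifluoromethyl)phenyl gives a number 4.8 percentage points lower from compound 2 to compound 3 (within the scatter) and so a six-membered aromatic ring of carbon only does not, on its own, set compound 3 apart from compound 2 at this position. Set against 4-fluorophenyl, the same group gives a number 21.8 percentage points lower from compound 1 to compound 3 (beyond the scatter) and so shows that two phenyl groups at this position can read differently, leaving compound 1 with both of its steps beyond the scatter. No measurement at hand accounts for these differences.

Still open, as far as these compounds go, is whether the gap between compound 1 and compound 3 follows the substituent itself or where it sits on the phenyl ring. Also open, from the compounds shown here alone, is how an unsubstituted phenyl, an amine or a carboxylic acid at this position would read.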